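Swapping the halogenated aryl on the enone chain of compound 1

A few compounds are considered here, and "the series" means these few. Any claim that something is new, unique, unknown or untested is made for them only; others in the source may bear on it.

Compound 1 `O=C(COc1ccc(C(=O)/C=C/c2ccccc2Br)cc1)N[C@H]1CCOC1=O` is the stronger of the two numbered results in a functional assay on PC-3 cells (Homo sapiens) for antiproliferative activity, read by MTT assay, with a stated time of 72 h (on this read-out higher numbers stand for weaker inhibition and lower numbers for stronger inhibition), where compound 1 gives 3260 nM. Compound 3 `O=C1OCC[C@@H]1NC(=S)SCCOc1ccccc1[N+](=O)[O-]` gives 24000 nM in this assay, a weaker result that lies beyond the usual scatter. For compound 2 `O=C(CNc1ccccc1Cl)N[C@H]1CCOC1=O` this assay reports only a limit, > 64000 nM, and (the limit of > 64000 nM in this assay, at which 1 of the 3 values shown sits). Compound 4 `O=C(COc1ccc(C(=O)/C=C/c2ccc(F)cc2)cc1)N[C@H]1CCOC1=O` keeps the core of compound 1 and differs by 4-fluorophenyl in place of 2-bromophenyl on a double-bonded chain carbon bound to a double-bonded chain carbon. Within the data shown here, with no measured step of this kind to lean on, a modest loss is expected, a 1.4-fold higher number from compound 1 to compound 4 (0.14 log units; within the scatter), near the edge of the scatter. Compound 4 is therefore estimated at 4500 nM in this assay, with a range from 1500 nM to 14000 nM.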

Compound 4, half-maximal inhibitory concentration: 15600 nM
Compound 4: middle estimate off by 3.5-fold (0.54 log units), on the low side, outside the stated range (above it).
By their numbers in this assay, from the lowest: compound 1; then compounds 4 and 3 (each within the scatter of the next). At a limit, above all of these: compound 2.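

Among these compounds, this is the first step between two compounds that differ in one place, and it shows that the position on a double-bonded chain carbon bound to a double-bonded chain carbon responds to the aryl group it carries: in this assay, 4-fluorophenyl in place of 2-bromophenyl gives a 4.8-fold higher number from compound 1 to compound 4 (0.68 log units; beyond the scatter) while the shared core stays the same. Nothing measured here accounts for the size of this step.

The halogen and its place on the ring change together, leaving their shares in the step unseparated. As far as these compounds go, it also remains open how 4-bromophenyl, or a phenyl ring carrying an amine or a carboxylic acid, would read here.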